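Leaving the 1-aminocyclopentyl group of compound 2

The source may hold more compounds than are shown below. What is called first, only, known or untested is meant among the compounds shown, and "the series" means these compounds.

In an in vitro ADME assay on microsomes (Rattus norvegicus) for metabolic stability (on this read-out lower numbers stand for a shorter-lived compound and higher numbers for a longer-lived compound), compound 1 `CC[C@H](N)C(=O)N1CCc2c(C)c3c(n2-c2ccc(C(N)=O)c(c2)N[C@@H](C)[C@H](C)C1)CC(C)(C)CC3=O` gives > 0.5 h, which is a limit of the assay. Going by the values given here, compound 2 `Cc1c2c(n3c1CCN(C(=O)C1(N)CCCC1)C[C@@H](C)[C@H](C)Nc1cc-3ccc1C(N)=O)CC(C)(C)CC2=O` gives 0.0833 h, the shorter half-life of the pair and the only exact number so far. Compound 3 `Cc1c2c(n3c1CCN(C(=O)[C@H](C)O)C[C@@H](C)[C@H](C)Nc1cc-3ccc1C(N)=O)CC(C)(C)CC2=O` has 1-hydroxyethyl in place of 1-aminocyclopentyl on a carbonyl carbon. Among the compounds with values here, the one measured step that bears on this, an at least 6.0-fold lower number from compound 1 to compound 2 (0.77 log units; beyond the scatter), ends at the group that compound 3 lacks. A rise of similar size is therefore expected, and the expected step is a 4.2-fold higher number from compound 2 to compound 3 (0.62 log units; beyond the scatter). Compound 3 is estimated at 0.35 h, with an expected range of 0.12 h to 1 h.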

Compound 3, half-life: 0.483 h
For compound 3 the middle estimate is 1.4-fold (0.14 log units) below the measured one, and the stated range covers the measured number.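

In this assay, 1-hydroxyethyl in place of 1-aminocyclopentyl on a carbonyl carbon gives a modest step: a 5.8-fold higher number from compound 2 to compound 3 (0.76 log units; beyond the scatter). Across these three compounds, a group with no nitrogen can therefore also stand clear of compound 2, and 1-aminocyclopentyl is the one group with the short half-life. The value of compound 1 is a limit: the limit of > 0.5 h in this assay, at which 1 of the 3 values shown sits. Measured against that limit, the data give an at least 1.0-fold lower number from compound 1 to compound 3 (0.01 log units; that floor lies within the scatter), and this floor leaves open how the two compare.

The compounds shown do not separate the cyclopentyl ring from the amine as the feature tied to the short half-life. A 1-hydroxycyclopentyl group at this place would bear on that.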